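The source may report more compounds than this note shows. Statements on the series, on what has been measured and on what is new or still open speak of the compounds shown alone.

In a functional assay on HOS cells (Homo sapiens) for antiproliferative activity, read by sulforhodamine B assay (a higher number here means a weaker inhibitor of growth, a lower number a stronger inhibitor of growth), compound 1 (`CCC[C@@H]1O[C@H](COCc2ccccc2)[C@@H](OCc2ccccc2)[C@H](OCc2ccccc2)C1=O`) gives > 50000 nM as a limit and not a number. Compound 2 (`CC(C)C[C@@H]1O[C@H](COCc2ccccc2)[C@@H](OCc2ccccc2)[C@H](OCc2ccccc2)C1=O`) gives > 50000 nM as a limit too. Compound 3 (`CCCCC[C@@H]1O[C@H](COCc2ccccc2)[C@@H](OCc2ccccc2)[C@H](OCc2ccccc2)C1=O`) also gives > 50000 nM as a limit. All three therefore sit together (the limit of > 50000 nM in this assay, at which 3 of the 3 values shown sit). Compound 4 (`C=CC[C@@H]1O[C@H](COCc2ccccc2)[C@@H](OCc2ccccc2)[C@H](OCc2ccccc2)C1=O`) carries vinyl in place of butyl on a saturated chain carbon bound to a saturated ring carbon. Among the compounds with values here, the measured steps offer no size to carry over: the first is a step that the two limits leave unreadable from compound 1 to compound 2 while the next is a step that the two limits leave unreadable from compound 1 to compound 3 and the last is a step that the two limits leave unreadable from compound 2 to compound 3 in the same way. With all three chains at that limit, no step beyond the scatter is expected in this assay in either direction. The step expected is a step that the limit leaves unreadable from compound 3 to compound 4 on this estimate. For compound 4 the estimated value is 60000 nM with a range from 30000 nM to 120000 nM and most likely only a limit will be reported.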

Compound 4, concentration for 50% growth inhibition: 7600 nM
For compound 4 the middle estimate is 7.9-fold (0.90 log units) above the measured one; measured number outside the range, below it.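

Until now, every chain at this place, on a saturated chain carbon bound to a saturated ring carbon, sat at one limit: the limit of > 50000 nM in this assay, at which 3 of the 4 values shown sit.

Within the data shown here, compound 4 gives the first measured value in this assay, with an at least 6.5-fold lower number from compound 3 to compound 4 (0.81 log units; beyond the scatter), an at least 6.5-fold lower number from compound 2 to compound 4 (0.81 log units; beyond the scatter) and an at least 6.5-fold lower number from compound 1 to compound 4 (0.81 log units; beyond the scatter). The last step swaps ethyl for vinyl, so the gain goes with the double bond and not only with a shorter chain.

As far as these compounds go, whether a triple bond, a longer chain ending in a double bond, or an amine at this place would keep this growth inhibition stays open. From the compounds shown here alone, the true sizes of these steps also stay open, since each starts from a limit.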